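The source may report more compounds than this note shows. Statements on the series, on what has been measured and on what is new or still open speak of the compounds shown alone.

Compound 3 `CC(C)Oc1cc(NC(=O)Nc2cc(Cl)nc(Cl)c2)cc(Cl)n1` gives 21100 nM in an ADME assay on NCM460 cells (Homo sapiens) for cytotoxicity, read by MTT assay, with a stated time of 72 h, in the presence of a further agent that is not named here (on this read-out higher numbers stand for an effect only at larger amounts of compound and lower numbers for an effect already at smaller amounts), against 25300 nM for compound 2 `CCOc1cc(NC(=O)Nc2cc(Cl)nc(Cl)c2)cc(Cl)n1` and 55300 nM for compound 1 `O=C(Nc1ccnc(Cl)c1)Nc1cc(Cl)nc(Cl)c1`. The gap a 1.2-fold lower number from compound 2 to compound 3 (0.08 log units; within the scatter) is within the scatter, whereas a 2.6-fold lower number from compound 1 to compound 3 (0.42 log units; beyond the scatter) and a 2.2-fold lower number from compound 1 to compound 2 (0.34 log units; beyond the scatter) lie beyond it. Compound 4 `O=C(Nc1cc(Cl)nc(Cl)c1)Nc1cc(Cl)nc(OC2CCCC2)c1` differs from compound 3 by cyclopentyl in place of isopropyl on an oxygen on an aromatic ring. For the measured compounds named here, the only step that bears on enlarging the group on this oxygen is a 1.2-fold lower number from compound 2 to compound 3 (0.08 log units; within the scatter), which was within the scatter, so for the step to compound 4 no change beyond the scatter is expected, and the estimated 1.2-fold lower number from compound 3 to compound 4 (0.09 log units; within the scatter) stays small. Compound 4 is therefore expected to give about 17000 nM, in a range from 8000 nM to 40000 nM.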

Compound 4, half-maximal effective concentration: 21400 nM
Estimate against measurement, compound 4: 1.3-fold (0.10 log units) below; measured number inside the range.
By their numbers in this assay, from the lowest: compounds 3, 4 and 2 (each within the scatter of the next); then compound 1.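

In this assay, cyclopentyl brings a ring onto the oxygen on an aromatic ring, yet a 1.0-fold higher number from compound 3 to compound 4 (0.01 log units; within the scatter) and a 1.2-fold lower number from compound 2 to compound 4 (0.07 log units; within the scatter), so ethyl, isopropyl and cyclopentyl cannot be told apart here. The step beyond the scatter remains the one from hydrogen on the aromatic carbon, with a 2.6-fold lower number from compound 1 to compound 4 (0.41 log units; beyond the scatter). Nothing measured here explains this flat response to the group on the oxygen. The compounds shown leave open whether a longer chain on this oxygen, or an amine or a carboxylic acid carried on that group, would move the number beyond the scatter.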